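Ester chain length and topoisomerase inhibition

The source may report more compounds than this note shows. Statements on the series, on what has been measured and on what is new or still open speak of the compounds shown alone.

Measured compounds:
compound 1 `C=CCCCCC(=O)O[C@H](CC=C(C)C)C1=CC(=O)c2c(O)ccc(O)c2C1=O`: 250000 nM
compound 2 `CCCCCCCCCCCC(=O)O[C@H](CC=C(C)C)C1=CC(=O)c2c(O)ccc(O)c2C1=O`: a limit only, > 625000 nM

In an assay on HeLa cells for inhibition of DNA topoisomerase 1 (Homo sapiens) (on this read-out higher numbers stand for weaker inhibition and lower numbers for stronger inhibition), compound 1 gives 250000 nM. For compound 2 this assay reports only a limit, > 625000 nM. For the measured compounds named here, the single measured step, an at least 2.5-fold higher number from compound 1 to compound 2 (0.39 log units; beyond the scatter), goes toward weaker inhibition, and compound 2 sits at the limit of > 625000 nM in this assay, at which 1 of the 2 values shown sits. Compound 3 `CCCCCCCCCCC(=O)O[C@H](CC=C(C)C)C1=CC(=O)c2c(O)ccc(O)c2C1=O` differs from compound 2 by hydrogen in place of methyl on a saturated chain carbon, ten or more bonds along the chain from a carbonyl carbon. Against the measured heptyl-for-vinyl step this is a minor change, so no movement beyond the scatter is expected, and an at least 1.0-fold lower number from compound 2 to compound 3 (0.01 log units; that floor lies within the scatter) is the estimated step. Compound 3 is expected to give about 600000 nM, within 250000 nM to 1500000 nM, most likely again as a limit.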

Compound 3, half-maximal inhibitory concentration: > 625000 nM
Compound 3 gave a limit, no number; the forecaster's own chance of this, stated with the estimate: 70%; at least 1.0-fold (0.01 log units) between middle value and limit.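

With hexyl in place of vinyl on the saturated chain carbon four bonds along the chain from a carbonyl carbon, the shift toward weaker inhibition holds, as it did with heptyl: an at least 2.5-fold higher number from compound 1 to compound 3 (0.39 log units; beyond the scatter). The step between compound 2 and compound 3 cannot be read, as both values are limits: the limit of > 625000 nM in this assay, at which 2 of the 3 values shown sit.

The compounds shown do not separate the length of the chain from the presence of the vinyl end. From the compounds shown here alone, whether a shorter saturated chain, or an amine or carboxylic acid at the chain end, would give stronger inhibition than compound 1 stays open.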